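The source may report more compounds than this note shows. Statements on the series, on what has been measured and on what is new or still open speak of the compounds shown alone.

Working notes on the series. Compound 1 `CCNC(=O)c1cc(N)c(Nc2ccc(C#N)cc2)cc1Oc1c(C)cc(/C=C/C#N)cc1C` and compound 2 `COC(=O)c1cc(N)c(Nc2ccc(C#N)cc2)cc1Oc1c(C)cc(/C=C/C#N)cc1C` share one core and differ only at the carbonyl carbon. In a physicochemical assay for lipophilicity, read by HPLC, measured as octanol-water partition, with a stated time of 24 h, at pH 7.4 (a higher number here means a more lipophilic compound, a lower number a more polar compound), compound 1 gives 3.63, and in this assay compound 2 gives 4.15; the change was a number 0.52 log units higher from compound 1 to compound 2 (beyond the scatter). Compound 2 therefore stands highest of the two numbers measured, with compound 1 as its nearest neighbour beyond the scatter. Compound 3 `Cc1cc(/C=C/C#N)cc(C)c1Oc1cc(Nc2ccc(C#N)cc2)c(N)cc1C(=O)OCCC#N` is not yet measured; it carries cyanomethyl in place of hydrogen on a saturated chain carbon bound to an oxygen next to a carbonyl group. Among the compounds with values here, only one measured step bears on this change, and only by its place: the step from compound 1 to compound 2 also altered the group on the carbonyl carbon, at a number 0.52 log units higher from compound 1 to compound 2 (beyond the scatter), but it exchanged the whole group rather than lengthening the chain bound to the ester oxygen, and no measured pair adds a nitrile. The step from compound 2 to compound 3 is therefore expected to be a number 0.05 log units lower from compound 2 to compound 3 (within the scatter), within the scatter. Compound 3 is estimated at 4.1 in this assay, with a range from 3.7 to 4.5.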

Compound 3, partition coefficient: > 5
Compound 3 ended at the assay's limit (the forecaster's own chance of this, stated with the estimate: 0%); middle value at least 0.90 log units away from the limit.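

In this assay compound 3 reads > 5, which is a limit of the assay and not a number: the limit of > 5 in this assay, at which 1 of the 3 values shown sits.
Cyanomethyl in place of hydrogen on a saturated chain carbon bound to an oxygen next to a carbonyl group gives a number at least 0.85 log units higher from compound 2 to compound 3 (beyond the scatter), so a change confined to the ester chain, with the carbonyl carbon's methoxy extended to 2-cyanoethoxy, moves this read-out beyond the scatter. With 2-cyanoethoxy in place of ethylamino on the carbonyl carbon, the step is a number at least 1.37 log units higher from compound 1 to compound 3 (beyond the scatter), wider than the earlier exchange of the whole group, a number 0.52 log units higher from compound 1 to compound 2 (beyond the scatter).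

Going by these compounds, the true size of both new steps stays open, since each rests on a limit. Also open, on these data alone, is how the step divides between the nitrile and the added carbons, a question that a propyl chain on the ester oxygen would address.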